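Adding a third methoxy to compound 2

A few compounds are considered here, and "the series" means these few. Any claim that something is new, unique, unknown or untested is made for them only; others in the source may bear on it.

Going by the values given here, compound 2 `COc1ccc(/C=C/C2CC(=O)C=CO2)cc1OC` gives the lowest of the two numbers so far in a functional assay on HT-29 cells (Homo sapiens) for inhibition, read by sulforhodamine B assay, with a stated time of 48 h (on this read-out higher numbers stand for weaker inhibition of growth and lower numbers for stronger inhibition of growth), at 123 uM; its nearest neighbour is compound 1 `COc1ccc(/C=C/C2CC(=O)C=CO2)cc1`, which gives 204 uM, and the gap between them is within the scatter. Compound 3 `COc1cc(/C=C/C2CC(=O)C=CO2)cc(OC)c1OC` differs from compound 2 by methoxy in place of hydrogen on an aromatic carbon. Among the compounds with values here, the one measured step that bears on this change is a 1.7-fold lower number from compound 1 to compound 2 (0.22 log units; within the scatter), the same kind of change on an aromatic carbon. A step of similar size in the same direction, or none beyond the scatter, is therefore expected, estimated as a 1.3-fold lower number from compound 2 to compound 3 (0.11 log units; within the scatter). For compound 3 the expected value in this assay is 95 uM, with a range of 40 uM to 230 uM.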

Compound 3, concentration for growth inhibition (reported as GI): 135 uM
The estimate for compound 3 lay 1.4-fold (0.15 log units) below the measured number; measured number inside the range.
By their numbers in this assay, from the lowest: compounds 2, 3 and 1 (each within the scatter of the next).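

The third methoxy, on the aromatic carbon ortho to a methoxy group, gives a 1.1-fold higher number from compound 2 to compound 3 (0.04 log units; within the scatter) in this assay, so filling this position leaves the number within the scatter. With a 1.7-fold lower number from compound 1 to compound 2 (0.22 log units; within the scatter) as well, neither methoxy step in this series moves the number beyond the scatter. Nothing at hand offers a reason for this flat result. Open, on these data alone, is whether an amine, a carboxylic acid or a longer chain such as butoxy at this position would give a step beyond the scatter. Also open, as far as these compounds go, is whether any change to the shared core would do so.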